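Defining the stereocentres of compound 3 in the series

A few compounds are considered here, and "the series" means these few. Any claim that something is new, unique, unknown or untested is made for them only; others in the source may bear on it.

Of the compounds shown here, three in this set have been tested for their affinity in an assay on HEK293 cells for binding affinity to prostaglandin E2 receptor EP2 subtype (Rattus norvegicus); on this read-out lower numbers stand for stronger inhibition and higher numbers for weaker inhibition. Compound 1 `O=C(O)CCCCCCN1C(=O)CC[C@@H]1CCC(O)Cc1ccccc1` gives only a limit of the assay in this assay, > 3200 nM. Going by the values given here, compound 2 `O=C(O)c1ccc(CCCN2C(=O)CC[C@@H]2CCC(O)Cc2ccccc2)s1` gives 690 nM in this assay, and the single measured step, an at least 4.6-fold lower number from compound 1 to compound 2 (0.66 log units; beyond the scatter), moves the number well beyond the scatter. Compound 3 `O=C(O)CCCCCCN1C(=O)CCC1CCC(O)CCc1ccccc1` likewise gives only a limit in this assay, > 3200 nM, so it stands among the weaker members as far as the numbers show; the limit of > 3200 nM in this assay, at which 2 of the 3 values shown sit, marks where both limits sit.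

Compound 4 `O=C(O)CCCCCCN1C(=O)CC[C@@H]1CC[C@@H](O)CCc1ccccc1` differs from compound 3 only in stereochemistry: the two compounds have the same atoms and bonds; at least one stereo element is drawn with a configuration in one of them and without one in the other: 2 of 2 stereo elements differ; a stereocentre at a saturated ring carbon is drawn without a configuration in compound 3 and S in compound 4; a stereocentre at a saturated chain carbon is drawn without a configuration in compound 3 and S in compound 4. Among the compounds with values here, no measured step in this set changes a stereocentre alone, and the step from compound 1 to compound 2 concerns a different part of the molecule, so it does not bear directly on this change. Since compound 3 gives only a limit, the undefined mixture leaves room for one defined isomer to bind more strongly, though it may equally stay at the limit. Compound 4 is therefore expected to give about 2500 nM in this assay, within a range of 700 nM to 8000 nM, and the expected step from compound 3 to compound 4 is an at least 1.2-fold lower number from compound 3 to compound 4 (0.10 log units; that floor lies within the scatter).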

Compound 4, half-maximal inhibitory concentration: > 3200 nM
Compound 4: only a limit was reported; the forecaster's own chance of this, stated with the estimate: 55%; middle value at least 1.2-fold (0.10 log units) away from the limit.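

No step can be read from compound 3 to compound 4, because both give only a limit in this assay: the limit of > 3200 nM in this assay, at which 3 of the 4 values shown sit.

The compounds shown leave open how compound 4 and the other defined stereoisomers of compound 3 truly rank, and whether any configuration at these two stereocentres matters.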